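The compounds below may be only part of what the source reports. "The series", "measured", "known", "first", "only" and "open" are said of these compounds alone.

Measured so far:
compound 1, `Cc1ccc(S(=O)(=O)N(C)CCCN(C)C)cc1C#Cc1cc(Cl)ccc1OCC(=O)O`: 287 nM
compound 2, `Cc1ccc(S(=O)(=O)N2CCCCC2C)cc1C#Cc1cc(Cl)ccc1OCC(=O)O`: 1.9 nM

Both compounds share a core that carries a sulfonyl group on one ring, and they differ only in what sits on that sulfonyl sulfur. In an assay on CHO cells for displacement of a labelled ligand from prostaglandin D2 receptor 2 (Homo sapiens), read by scintillation counting (on this read-out higher numbers stand for weaker inhibition and lower numbers for stronger inhibition), compound 1 gives 287 nM, whereas compound 2 gives 1.9 nM, the lower of the two numbers and thus the stronger binder here; the step of a 150-fold lower number from compound 1 to compound 2 (2.18 log units; beyond the scatter) shows how much the group on the sulfonyl sulfur matters.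

Compound 3, `Cc1ccc(S(C)(=O)=O)cc1C#Cc1cc(Cl)ccc1OCC(=O)O`, is the not yet measured member. Its change from compound 2 is methyl in place of 2-methylpiperidin-1-yl on a sulfonyl sulfur, so the ring is cut away and only a single carbon remains on the sulfur. Among the compounds with values here, only one measured step bears on this position, a 150-fold lower number from compound 1 to compound 2 (2.18 log units; beyond the scatter), and it is large. Since that step says the sulfonyl substituent strongly sets the number, removing the ring altogether is expected to raise the number in this assay by a sizeable amount. The estimate for compound 3 is 100 nM, with a range from 15 nM to 800 nM, which corresponds to an expected step of a 53-fold higher number from compound 2 to compound 3 (1.72 log units; beyond the scatter).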

Compound 3, inhibition constant: 5 nM
Compound 3: the middle estimate sits 20-fold (1.30 log units) above what was measured; the measured number lies below the stated range.
By their numbers in this assay, from the lowest: compound 2; then compound 3; then compound 1.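

Cutting the group on the sulfonyl sulfur down to methyl costs much less than the earlier pair suggested: in this assay the change gives a 2.6-fold higher number from compound 2 to compound 3 (0.42 log units; beyond the scatter), a modest step, though still beyond the usual scatter. The ring of 2-methylpiperidin-1-yl is therefore not required for a low number, and the high number of compound 1 now stands out, since a single carbon on the sulfur already gives a 57-fold lower number from compound 1 to compound 3 (1.76 log units; beyond the scatter), a large step of the same kind as a 150-fold lower number from compound 1 to compound 2 (2.18 log units; beyond the scatter). Nothing available here accounts for this order among the three groups.

The compounds shown leave open whether ethyl, or a piperidin-1-yl ring without its methyl, would give a number closer to that of compound 2 or to that of compound 3. They also leave open whether the high number of compound 1 goes with its dimethylamino group or with the length of its chain, a question that a plain propyl chain on the sulfonamide nitrogen could help to separate.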